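The source may report more compounds than this note shows. Statements on the series, on what has been measured and on what is new or still open speak of the compounds shown alone.

For the measured compounds named here, in a functional assay (aorta) with Oryctolagus cuniculus as the target (on this read-out higher numbers stand for weaker inhibition and lower numbers for stronger inhibition), compound 1 (`CC1=C(C)C(=O)C(C(CCCCCCC(=O)O)c2ccccc2)=C(C)C1=O`) gives 3200 nM as the higher of the two numbers so far, while compound 2 (`CC1=C(C)C(=O)C(C(CCCCCC(=O)O)c2cccs2)=C(C)C1=O`) gives 760 nM and lies lower by more than the usual scatter. Compound 3 (`COC(=O)CCCCCC(C1=C(C)C(=O)C(C)=C(C)C1=O)c1ccccc1`) awaits measurement. Its change from compound 1 (methoxycarbonyl in place of carboxymethyl on a saturated chain carbon, six bonds along the chain from an aromatic carbon and a double-bonded ring carbon) puts methoxycarbonyl in place of carboxymethyl on a saturated chain carbon, six bonds along the chain from an aromatic carbon and a double-bonded ring carbon. Going by the values given here, no measured pair shows this change, so the expectation is tentative: a move toward weaker inhibition, with an estimated step (a 2.8-fold higher number from compound 1 to compound 3 (0.45 log units; beyond the scatter)) probably beyond the scatter. Compound 3 is expected at 9000 nM (range 2500 nM to 35000 nM) once measured.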

Compound 3, half-maximal inhibitory concentration: 1400 nM
For compound 3 the middle estimate is 6.4-fold (0.81 log units) above the measured one; the measured number lies below the stated range.
By their numbers in this assay, from the lowest: compounds 2 and 3 (each within the scatter of the next); then compound 1.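

In this assay, putting methoxycarbonyl in place of carboxymethyl on a saturated chain carbon, six bonds along the chain from an aromatic carbon and a double-bonded ring carbon, gives a 2.3-fold lower number from compound 1 to compound 3 (0.36 log units; beyond the scatter), a modest step. The atoms stay the same, so their rearrangement at this position alone moves the number. Compound 3 carries no free carboxylic acid, yet inhibits more strongly than compound 1, and nothing available explains this shift. On these data alone, whether a primary amide or an ethyl ester at this position would move the number further remains open.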